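Alkenyl amides: the step from compound 3 to compound 4

A few compounds are considered here, and "the series" means these few. Any claim that something is new, unique, unknown or untested is made for them only; others in the source may bear on it.

Measured in a functional assay on A549 cells (Homo sapiens) for inhibition, read by MTT assay, with a stated time of 72 h; on this read-out higher numbers stand for weaker inhibition and lower numbers for stronger inhibition:
- compound 1 `C=C(Cl)C(=O)Nc1cc(Nc2nc3c(c(-c4cn(C)c5ccccc45)n2)CSCC3)c(OC)cc1N(C)CCN(C)C`: 716 nM
- compound 2 `COc1cc(N(C)CCN(C)C)c(NC(=O)C=C(C)C)cc1Nc1nc2c(c(-c3cn(C)c4ccccc34)n1)CSCC2`: 583 nM
- compound 3 `C/C=C\C(=O)Nc1cc(Nc2nc3c(c(-c4cn(C)c5ccccc45)n2)CSCC3)c(OC)cc1N(C)CCN(C)C`: 6860 nM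

Compound 3 has the highest number of the three, 6860 nM. The other two lie within the scatter of each other: a 1.2-fold lower number from compound 1 to compound 2 (0.09 log units; within the scatter).

Compound 4 `COc1cc(N(C)CCN(C)C)c(NC(=O)/C=C\C(C)C)cc1Nc1nc2c(c(-c3cn(C)c4ccccc34)n1)CSCC2` differs from compound 3 by one change: isopropyl in place of methyl on a double-bonded chain carbon bound to a double-bonded chain carbon. Cut one bond further out, this reads prop-1-en-1-yl to 3-methylbut-1-en-1-yl.

For the measured compounds named here, two measured steps bear on it: a 9.6-fold higher number from compound 1 to compound 3 (0.98 log units; beyond the scatter) and a 12-fold higher number from compound 2 to compound 3 (1.07 log units; beyond the scatter), both beyond the scatter. They show that changes on this carbonyl carbon can move the number substantially in this assay. Neither of them is a change from methyl to isopropyl, so they give no firm direction here. No step beyond the scatter is therefore expected, and the estimated step is a 1.7-fold lower number from compound 3 to compound 4 (0.23 log units; within the scatter). For compound 4 the estimated value is 4000 nM, with an expected range of 1200 nM to 12000 nM.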

Compound 4, half-maximal inhibitory concentration: 788 nM
For compound 4 the middle estimate is 5.1-fold (0.71 log units) above the measured one; measured number outside the range, below it.
By their numbers in this assay, from the lowest: compounds 2, 1 and 4 (each within the scatter of the next); then compound 3.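

In this assay, isopropyl in place of methyl on a double-bonded chain carbon bound to a double-bonded chain carbon gives an 8.7-fold lower number from compound 3 to compound 4 (0.94 log units; beyond the scatter), so this position responds to a change of the alkyl group on the alkene itself, not only to the changes seen earlier on the carbonyl carbon. The comparisons with the other two amides read a 1.4-fold higher number from compound 2 to compound 4 (0.13 log units; within the scatter) and a 1.1-fold higher number from compound 1 to compound 4 (0.04 log units; within the scatter), which leaves compound 3, with its prop-1-en-1-yl group, as the only one of the four set apart by steps beyond the scatter. No evidence on the origin of the step from methyl to isopropyl is available.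

Open, as far as these compounds go, is whether ethyl, which lies between methyl and isopropyl in size of chain, falls with compound 3 or with compound 4. Also open, from the compounds shown here alone, is how a longer chain or a chain ending in an amine on the same carbon would read in this assay.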